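A few compounds are considered here, and "the series" means these few. Any claim that something is new, unique, unknown or untested is made for them only; others in the source may bear on it.

Working notes on the series, read in an in vitro ADME assay on microsomes from liver (Rattus norvegicus) for metabolic stability; on this read-out higher numbers stand for fast clearance and lower numbers for slow clearance. Among the compounds with values here, compound 1 `CC(C)NC(=O)[C@H]1CC[C@@H](n2/c(=N/C(=O)c3cc(F)cc(Cl)c3)[nH]c3ccc(CN4CCC(C(C)(C)O)CC4)cc32)CC1` gives 43 mL.min-1.g-1, the lower of the two numbers so far. Compound 2 `CCNC(=O)[C@H]1CC[C@@H](n2/c(=N/C(=O)c3ccccc3)[nH]c3ccc(CN4CCCCC4)cc32)CC1` gives 310 mL.min-1.g-1, a gap beyond the scatter, but the two compounds differ in more than one place, so that gap isolates no single group. Compound 3 `CC(C)NC(=O)[C@H]1CC[C@@H](n2/c(=N/C(=O)c3cccnc3)[nH]c3ccc(CN4CCC(C(C)(C)O)CC4)cc32)CC1` is not yet measured. It keeps the rest of compound 1 and carries pyridin-3-yl in place of 3-chloro-5-fluorophenyl on a carbonyl carbon. Within the data shown here, no measured pair shows this change on its own, so the expectation has little to rest on and its range is kept wide. A small move towards slower clearance, not beyond the scatter, is expected. The expected step is a 1.4-fold lower number from compound 1 to compound 3 (0.16 log units; within the scatter). Compound 3 is estimated at 30 mL.min-1.g-1, with an expected range from 13 mL.min-1.g-1 to 70 mL.min-1.g-1.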

Compound 3, intrinsic clearance in microsomes: < 14 mL.min-1.g-1
Compound 3: a limit, no number; the forecaster's own chance of this, stated with the estimate: 5%; middle value at least 2.1-fold (0.33 log units) from the limit.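

In this assay, within the data shown here, pyridin-3-yl in place of 3-chloro-5-fluorophenyl on a carbonyl carbon is the first change that can be read on its own, and it gives an at least 3.0-fold lower number from compound 1 to compound 3 (0.48 log units; beyond the scatter). With the rest of compound 1 held fixed, this place alone therefore moves the read-out beyond the scatter, which the gap between the two earlier compounds could not show. Compound 3 stands as a limit of the assay and not a number, so the step has a bound but no measured size: the limit of < 14 mL.min-1.g-1 in this assay, at which 1 of the 3 values shown sits.

The change removes the chlorine and the fluorine and brings in the ring nitrogen at once, and the compounds shown do not separate these parts. Going by these compounds, how a fluorophenyl or a pyrimidinyl group would read at this place remains open.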